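A few compounds are considered here, and "the series" means these few. Any claim that something is new, unique, unknown or untested is made for them only; others in the source may bear on it.

Compound 1 `Cc1cn([C@@H]2O[C@H](CO[Si](C)(C)C(C)(C)C)[C@@]3(OS(=O)(=O)C=C3NCC(=O)C(N)=O)[C@H]2O[Si](C)(C)C(C)(C)C)c(=O)n(C)c1=O` – 14500 nM
Compound 2 `CCNC(=O)NC1=CS(=O)(=O)O[C@@]12[C@@H](CO[Si](C)(C)C(C)(C)C)O[C@@H](n1cc(C)c(=O)n(C)c1=O)[C@@H]2O[Si](C)(C)C(C)(C)C` – 10000 nM

In a functional assay on HEL cells (Homo sapiens) (on this read-out higher numbers stand for lower toxicity in this test and lower numbers for higher toxicity in this test), compound 2 gives 10000 nM, within the scatter of compound 1 . Compound 3 `COC(=O)CCNC1=CS(=O)(=O)O[C@@]12[C@@H](CO[Si](C)(C)C(C)(C)C)O[C@@H](n1cc(C)c(=O)n(C)c1=O)[C@@H]2O[Si](C)(C)C(C)(C)C` differs from compound 2 as follows: 2-(methoxycarbonyl)ethyl in place of ethylcarbamoyl on an amine nitrogen. In words, it has 2-(methoxycarbonyl)ethyl in place of ethylcarbamoyl on an amine nitrogen. Going by the values given here, the only measured step at this place is a 1.5-fold lower number from compound 1 to compound 2 (0.16 log units; within the scatter). That one step, a different exchange, gives no sign of a large effect, so no change beyond the scatter is expected. The expected step is a 1.1-fold higher number from compound 2 to compound 3 (0.04 log units; within the scatter). The estimate for compound 3 is 11000 nM, with an expected range from 5000 nM to 24000 nM.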

Compound 3, half-maximal cytotoxic concentration: 94000 nM
For compound 3 the middle estimate is 8.5-fold (0.93 log units) below the measured one, and the stated range ends below it.
By their numbers in this assay, from the lowest: compounds 2 and 1 (each within the scatter of the next); then compound 3.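

In this assay, going by these compounds alone, the substituent on this amine nitrogen proves able to move the number beyond the scatter, which the one earlier exchange did not show: 2-(methoxycarbonyl)ethyl in place of ethylcarbamoyl gives a 9.4-fold higher number from compound 2 to compound 3 (0.97 log units; beyond the scatter). The other comparison points the same way, with a 6.5-fold higher number from compound 1 to compound 3 (0.81 log units; beyond the scatter), so compound 3 shows the lowest toxicity of the three in this test. No evidence is available on what lies behind this step. Going by these compounds, it remains open whether the result follows the methyl ester or the chain carrying it. A carboxylic acid in place of the ester, or a longer chain ending in the ester, would help separate the two.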